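The source may report more compounds than this note shows. Statements on the series, on what has been measured and on what is new or still open speak of the compounds shown alone.

In a functional assay on K562 cells (Homo sapiens) for inhibition, read by trypan blue exclusion, with a stated time of 72 h (a higher number here means a weaker inhibitor, a lower number a stronger inhibitor), compound 3 `O=c1c(S(=O)(=O)c2ccc(F)cc2F)cc2cnc(Nc3ccc4[nH]ccc4c3)nc2n1CC1CCCC1` gives 7000 nM. It lies within the scatter of compound 1 `O=c1c(S(=O)(=O)c2ccc(F)cc2F)cc2cnc(Nc3ccc4[nH]ccc4c3)nc2n1C1CCCC1` at 5000 nM, and is clearly weaker than compound 2 `CCn1c(=O)c(S(=O)(=O)c2ccc(F)cc2F)cc2cnc(Nc3ccc4[nH]ccc4c3)nc21` at 750 nM. Compound 4 `O=c1c(S(=O)(=O)c2ccc(F)cc2F)cc2cnc(Nc3ccc4[nH]ccc4c3)nc2n1C1CC1` has cyclopropyl in place of cyclopentylmethyl on an aromatic nitrogen. The measured changes at this nitrogen bear directly on it. Two were modest, a 6.7-fold lower number from compound 1 to compound 2 (0.82 log units; beyond the scatter) and a 9.3-fold higher number from compound 2 to compound 3 (0.97 log units; beyond the scatter), and both favour ethyl, whereas a 1.4-fold higher number from compound 1 to compound 3 (0.15 log units; within the scatter) stays within the scatter. Cyclopropyl is nearer to ethyl than to the larger groups, but no cyclopropyl result exists yet. A modest fall is therefore expected in this assay, estimated as a 4.7-fold lower number from compound 3 to compound 4 (0.67 log units; beyond the scatter). Compound 4 is estimated at 1500 nM, with an expected range from 500 nM to 5000 nM.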

Compound 4, half-maximal inhibitory concentration: 500 nM
For compound 4 the middle estimate is 3.0-fold (0.48 log units) above the measured one; the measured number falls inside the stated range.
By their numbers in this assay, from the lowest: compounds 4 and 2 (each within the scatter of the next); then compounds 1 and 3 (each within the scatter of the next).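

In this assay, cyclopropyl on this aromatic nitrogen gives a 14-fold lower number from compound 3 to compound 4 (1.15 log units; beyond the scatter) and a 10-fold lower number from compound 1 to compound 4 (1.00 log units; beyond the scatter), so carrying a ring here does not by itself bring the higher numbers seen with the two larger groups. Cyclopropyl and ethyl cannot be told apart, with a 1.5-fold lower number from compound 2 to compound 4 (0.18 log units; within the scatter) lying within the scatter. No measurement shown explains why the two smaller groups give the lower numbers. Still open, on these data alone, is whether cyclobutyl would behave like cyclopropyl or like cyclopentyl, and whether a longer chain ending in an amine would be tolerated on this nitrogen.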